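Methyl for methylamino: working notes on compound 4

The source may report more compounds than this note shows. Statements on the series, on what has been measured and on what is new or still open speak of the compounds shown alone.

Compound 1 `Cc1ncnc2c1c(-c1cc3ccccc3o1)cn2[C@@H]1O[C@H](CO)[C@@H](O)[C@H]1O`: > 20000 nM (a limit)
Compound 2 `C#Cc1cn([C@@H]2O[C@H](CO)[C@@H](O)[C@H]2O)c2ncnc(C)c12`: 110 nM
Compound 3 `CNc1ncnc2c1c(I)cn2[C@@H]1O[C@H](CO)[C@@H](O)[C@H]1O`: > 20000 nM (a limit)

All three were tested in a functional assay on K562 cells (Homo sapiens), read by MTT assay, with a stated time of 72 h; on this read-out lower numbers stand for stronger inhibition and higher numbers for weaker inhibition. Compound 3 gives only a limit, > 20000 nM. This is the limit of > 20000 nM in this assay, at which 2 of the 3 values shown sit. Within the data shown here, compound 2 is the only one with a number, 110 nM.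

The step under study leads from compound 3 to compound 4 `Cc1ncnc2c1c(I)cn2[C@@H]1O[C@H](CO)[C@@H](O)[C@H]1O`: methyl in place of methylamino on an aromatic carbon. The methyl replaces methylamino on an aromatic carbon of a six-membered aromatic ring with 2 nitrogen.

Among the measured compounds shown here, no measured step covers this exchange directly. The closest evidence is an at least 180-fold lower number from compound 1 to compound 2 (2.25 log units; beyond the scatter), a large step beyond the scatter, but it concerns ethynyl in place of 1-benzofuran-2-yl on an aromatic carbon. Its relevance is narrow: compound 2 carries the entering methyl and reaches 110 nM, so a methyl-bearing compound can give a low number in this assay. Compound 1 goes against any general reading, since it also carries that methyl and stays at a limit.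

A lower number than that of compound 3 is therefore expected, though with little confidence in its size. The expected change is an at least 13-fold lower number from compound 3 to compound 4 (1.12 log units; beyond the scatter). For compound 4 the estimated value is 1500 nM, with an expected range from 100 nM to 20000 nM.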

Compound 4, half-maximal inhibitory concentration: > 20000 nM
Compound 4: only a limit was reported (the forecaster's own chance of this, stated with the estimate: 25%); middle value at least 13-fold (1.12 log units) from the limit.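

The methyl on the shared core does not by itself give a low number: iodo in place of ethynyl on an aromatic carbon brings an at least 180-fold higher number from compound 2 to compound 4 (2.25 log units; beyond the scatter) in this assay, so with that methyl held constant, the group on the other aromatic carbon decides the result between these two compounds. Compound 4 gives > 20000 nM, which is a limit of the assay. The steps to compound 4 from compound 1 and from compound 3 cannot be read, as each joins two limits, so methyl and methylamino cannot be ordered with iodo in place, and most of the series offers no numerical comparison: the limit of > 20000 nM in this assay, at which 3 of the 4 values shown sit.

From the compounds shown here alone, it remains open whether compound 2, with 110 nM, owes its low number specifically to ethynyl, or whether a nitrile or a vinyl group on the same aromatic carbon would also give a measurable value. Also open, going by these compounds, is how methylamino, or an unsubstituted amine, in place of methyl would read out when ethynyl is kept on the core.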